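This account rests on a few compounds, and the source may have more. Where it says the series, first, only, none or still open, it means among the compounds named here.

Measured in a functional assay on MCF7 cells (Homo sapiens) for antiproliferative activity, read by MTT assay, with a stated time of 48 h; on this read-out higher numbers stand for weaker inhibition and lower numbers for stronger inhibition:
Compound 1 `Cc1c(C(=O)N2CCCC(C)C2)oc2ccc(N(Cc3ccc(Br)cc3)S(=O)(=O)c3ccc(Br)cc3)cc12`: 32800 nM
Compound 2 `Cc1ccc(NC(=O)c2oc3ccc(N(Cc4ccc(Br)cc4)S(=O)(=O)c4ccc(Br)cc4)cc3c2C)nc1`: > 40000 nM, a limit of the assay and not a number
Compound 3 `Cc1c(C(=O)NCCNc2ccccc2)oc2ccc(N(Cc3ccc(Br)cc3)S(=O)(=O)c3ccc(Br)cc3)cc12`: not yet measured

Compound 2 has no true number, only the limit (the limit of > 40000 nM in this assay, at which 1 of the 2 values shown sits). Going on from it, compound 3 carries 2-anilinoethyl in place of 5-methylpyridin-2-yl on an amide-type nitrogen. For the measured compounds named here, only one measured step bears on this place, the exchange of 3-methylpiperidin-1-yl for (5-methylpyridin-2-yl)amino on a carbonyl carbon. That step, an at least 1.2-fold higher number from compound 1 to compound 2 (0.08 log units; that floor lies within the scatter), stays within the scatter. Going by the values given here, with compound 1 at 32800 nM as the only true number, no change beyond the scatter is expected in this assay, and the data give no firm direction. The expected step is an at least 1.3-fold lower number from compound 2 to compound 3 (0.12 log units; that floor lies within the scatter). Compound 3 is estimated at 30000 nM, with an expected range of 12000 nM to 50000 nM.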

Compound 3, half-maximal inhibitory concentration: > 40000 nM
Compound 3 ended at the assay's limit (the forecaster's own chance of this, stated with the estimate: 40%); middle value at least 1.3-fold (0.12 log units) from the limit.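

In this assay the amide nitrogen now carries 2-anilinoethyl, a chain ending in an aromatic ring of carbon only, and compound 3 gives > 40000 nM, a limit of the assay and not a number. For the compounds shown here, exchanging 3-methylpiperidin-1-yl for (2-anilinoethyl)amino on the carbonyl carbon gives an at least 1.2-fold higher number from compound 1 to compound 3 (0.08 log units; that floor lies within the scatter), so this second, differently built amide shows no stronger inhibition than the only true number in the set. The step between the two amides with a limit cannot be read: the limit of > 40000 nM in this assay, at which 2 of the 3 values shown sit.

From the compounds shown here alone, it remains open how far the true values of compound 2 and compound 3 lie from that limit. Going by these compounds, it is also open whether a different group on this carbonyl carbon, such as a morpholine or a chain ending in a dimethylamine, would bring the number clearly below that of compound 1.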